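Fluoro for hydrogen on the phenyl ring of compound 1

This account rests on a few compounds, and the source may have more. Where it says the series, first, only, none or still open, it means among the compounds named here.

Measured compounds:
- compound 1 `COc1cc(OC)cc(N2CCN(C(=O)c3onc(C)c3-c3ccccc3)CC2)c1`: 152 nM
- compound 2 `CCCc1nc(-c2ccc(OC)cc2)c(C(=O)N2CCN(c3cccc(Cl)c3)CC2)o1`: "not active" (no number reported)
- compound 3 `CCCc1nc(-c2ccc(OC)c(OC)c2)c(C(=O)N2CCN(c3cccc(Cl)c3)CC2)o1`: "not active" (no number reported)

For the measured compounds named here, in a functional assay on HL-60 cells (Homo sapiens) for inhibition, read by MTT assay, with a stated time of 72 h (on this read-out higher numbers stand for weaker inhibition and lower numbers for stronger inhibition), compound 1 gives 152 nM and is the only compound of the set with a number. Going by the values given here, compound 2 and compound 3, built on a different core, are reported only as not active in this assay, so no step between measured compounds can be read from these data.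

The next compound is compound 4 `COc1cc(OC)cc(N2CCN(C(=O)c3onc(C)c3-c3cccc(F)c3)CC2)c1`. It differs from compound 1 by the change (fluoro in place of hydrogen on an aromatic carbon), the same difference, cut one bond further out, reading phenyl to 3-fluorophenyl. The change enters a single heavy atom and no ring. With no measured step of this kind in the series, the expected step from compound 1 to compound 4 in this assay is small and within the scatter, in no fixed direction, and is estimated as a 1.2-fold lower number from compound 1 to compound 4 (0.07 log units; within the scatter).

Compound 4 is therefore expected to give about 130 nM in this assay, with a range from 50 nM to 400 nM.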

Compound 4, half-maximal inhibitory concentration: 152 nM
The estimate for compound 4 lay 1.2-fold (0.07 log units) below the measured number; the range from low to high includes it.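

In this assay, for the compounds shown here, fluoro in place of hydrogen on an aromatic carbon, meta to a large group, gives no change at the digits printed from compound 1 to compound 4 (within the scatter) and is the only step that can be read so far. At this position of the core of compound 1, then, phenyl to 3-fluorophenyl leaves the read-out within the scatter, which compound 1 alone could not show. No measurement at hand bears on the reason for this result.

Steps involving compound 2 and compound 3 cannot be read, as these compounds have a different core and carry no number. Still open, from the compounds shown here alone, is whether the same position accepts anything larger than fluoro, such as methoxy, an amine or a carboxylic acid, and whether fluoro at other carbons of the phenyl ring gives the same result.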